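Amide side chain switch on the N-ethyl series

The source may hold more compounds than are shown below. What is called first, only, known or untested is meant among the compounds shown, and "the series" means these compounds.

Compound 3 `CCn1c(C(=O)N[C@@H](C)CO)ccc1C(CC)(CC)c1ccc(OCC(O)C(C)(C)C)c(C)c1` stands at the lowest number of the three measured in an assay on HL-60 cells for agonist activity at vitamin D3 receptor (Homo sapiens), with a stated time of 96 h (on this read-out lower numbers stand for an effect already at smaller amounts and higher numbers for an effect only at larger amounts of compound), giving 1.06 nM. Its neighbours sit far away: compound 2 `CCC(CC)(c1ccc(OCC(O)C(C)(C)C)c(C)c1)c1ccc(C(=O)N[C@@H](C)CO)n1C` gives 570 nM and compound 1 `CCC(CC)(c1ccc(OCC(=O)C(C)(C)C)c(C)c1)c1ccc(C(=O)NCCC(=O)OC)n1C` gives 790 nM; those two values lie within the scatter of each other, although compound 1 carries a different amide side chain and a ketone in place of the alcohol, so nothing follows for the side chain from that pair alone. For the measured compounds named here, the only single-point step in the set is a 540-fold lower number from compound 2 to compound 3 (2.73 log units; beyond the scatter), which rests on the chain carbon bound to the aromatic nitrogen and not on the amide.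

Compound 4 `CCn1c(C(=O)NCCC(=O)O)ccc1C(CC)(CC)c1ccc(OCC(O)C(C)(C)C)c(C)c1` keeps the ethyl of compound 3 and changes the amide: 2-carboxyethyl in place of 1-(hydroxymethyl)ethyl on an amide-type nitrogen. Going by the values given here, no measured step isolates this change. What the set shows is that the amide side chain of compound 1 and that of compound 2, with the further ketone-to-alcohol difference, gave numbers within the scatter of each other. For compound 4 the change is therefore expected to be small in this assay, with the step of a 2.4-fold higher number from compound 3 to compound 4 (0.37 log units; beyond the scatter) estimated at or near the scatter. Compound 4 is estimated at 2.5 nM, with a range from 0.6 nM to 12 nM.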

Compound 4, half-maximal effective concentration: 33200 nM
Compound 4: middle estimate off by 13000-fold (4.12 log units), on the low side; measured number above the stated range.
By their numbers in this assay, from the lowest: compound 3; then compounds 2 and 1 (each within the scatter of the next); then compound 4.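

The amide side chain is not a silent place in this series: on the ethyl compounds, this assay gives a 31000-fold higher number from compound 3 to compound 4 (4.50 log units; beyond the scatter) for 2-carboxyethyl in place of 1-(hydroxymethyl)ethyl on the amide-type nitrogen. For the compounds shown here, until now the only single-point step was the one on the chain carbon bound to the aromatic nitrogen, a 540-fold lower number from compound 2 to compound 3 (2.73 log units; beyond the scatter), so the series now has two places where one change moves the number well beyond the scatter, and the low value of compound 3 depends on both its ethyl and its amide side chain. Nothing measured on hand accounts for the size of this step.

Going by these compounds alone, the change swaps the hydroxyl end for a carboxyl end, alters the chain and removes the defined stereocentre at once, so the single step does not tell which of these carries the loss; a 3-hydroxypropyl chain or a primary amide at the end of the chain would begin to separate them. Also open, going by these compounds, is whether an amine on the same chain, or the opposite configuration of the 1-(hydroxymethyl)ethyl group, would hold the number of compound 3.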